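The source may report more compounds than this note shows. Statements on the series, on what has been measured and on what is new or still open speak of the compounds shown alone.

Measured so far:
compound 1 `C=C1C(=O)O[C@H](c2ccc(OC)cc2)[C@H]1c1ccccc1`: 73%
compound 2 `C=C1C(=O)O[C@H](c2ccc(C)cc2)[C@H]1c1ccccc1`: 67%

In a functional assay on BXPC-3 cells (Homo sapiens) for cytotoxicity, read by MTT assay, with a stated time of 72 h, tested at 1 uM (a lower number here means a stronger effect, a higher number a weaker effect of the compound at the concentration tested), compound 2 gives 67%, the lowest of the two numbers, with compound 1 its nearest neighbour: a number 6 percentage points lower from compound 1 to compound 2 (within the scatter). Compound 3 `C=C1C(=O)O[C@H](c2ccc(C(F)(F)F)cc2)[C@H]1c1ccccc1` differs from compound 2 by trifluoromethyl in place of methyl on an aromatic carbon. Among the compounds with values here, the only measured step, a number 6 percentage points lower from compound 1 to compound 2 (within the scatter), also swapped a small group on that same aromatic carbon and stayed within the scatter, so no step beyond the scatter is expected here either. Compound 3 is therefore estimated at 62%, expected to fall between 45% and 80%, which means an expected step of a number 5 percentage points lower from compound 2 to compound 3 (within the scatter).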

Compound 3, a percentage reported as activity, at one concentration (the size of the read-out at that concentration, not a potency): 138%
The estimate for compound 3 lay 76 percentage points below the measured number, outside the stated range (above it).
By their numbers in this assay, from the lowest: compounds 2 and 1 (each within the scatter of the next); then compound 3.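

In this assay, the group on this aromatic carbon can matter a great deal: trifluoromethyl in place of methyl gives a number 71 percentage points higher from compound 2 to compound 3 (beyond the scatter), and trifluoromethyl in place of methoxy gives a number 65 percentage points higher from compound 1 to compound 3 (beyond the scatter). The earlier swap of methoxy for methyl stayed within the scatter, so not every small change here is harmless, and compound 3 shows the weakest effect of the three. As far as these compounds go, whether an amine or a carboxylic acid at this carbon would behave like trifluoromethyl or like methyl remains open. Nothing shown gives a reason for this jump.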